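The source may report more compounds than this note shows. Statements on the series, on what has been measured and on what is new or still open speak of the compounds shown alone.

Notes on a series sharing one core, shown for compound 1 as `Nc1nc(NC2CCCCC2)c2ncn(/C=C3/CC3(CO)CO)c2n1`. In an ADME assay on CCRF-HSB-2 cells (Homo sapiens) for cytotoxicity, with a stated time of 7 days (a lower number here means that less compound is tolerated, a higher number that more compound is tolerated), compound 1 gives > 20000 nM, which is a limit of the assay rather than a number. Compound 2 `CCCSc1nc(N)nc2c1ncn2/C=C1/CC1(CO)CO` gives 98000 nM in this assay. Compound 3 `CSc1nc(N)nc2c1ncn2/C=C1/CC1(CO)CO` gives > 100000 nM in this assay, again a limit. The change from compound 1 onward to a short chain on the same aromatic carbon appears twice among the measured steps, as a step that the limit leaves unreadable from compound 1 to compound 2 and a step that the two limits leave unreadable from compound 1 to compound 3; both stay unreadable due to the limit of > 20000 nM in this assay, at which 1 of the 3 values shown sits, and (the limit of > 100000 nM in this assay, at which 1 of the 3 values shown sits). The remaining measured step is an at least 1.0-fold higher number from compound 2 to compound 3 (0.00 log units; that floor lies within the scatter), which lies within the scatter. Compound 4 `CCOc1nc(N)nc2c1ncn2/C=C1/CC1(CO)CO` carries the change (ethoxy in place of cyclohexylamino on an aromatic carbon). Going by the values given here, the two measured steps that bear on it, both replacing cyclohexylamino with a short chain, gave no readable size, and the only readable step between short chains lay within the scatter. For compound 4 no movement beyond the scatter is therefore expected, with a fair chance that only a limit is reported. The expected step is a step that the limit leaves unreadable from compound 1 to compound 4. The estimate for compound 4 in this assay is 100000 nM, in the range 30000 nM to 300000 nM.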

Compound 4, half-maximal cytotoxic concentration: > 20000 nM
Compound 4: a limit, no number; the forecaster's own chance of this, stated with the estimate: 65%; the middle value lies beyond the limit too.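

In this assay compound 4 gives > 20000 nM, a limit of the assay and not a number. The steps linking compound 4 to compound 1, compound 2 and compound 3 cannot be read. The compounds shown leave open whether cyclohexylamino, ethoxy, methylsulfanyl and propylsulfanyl differ at all in this assay.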